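A few compounds are considered here, and "the series" means these few. Any claim that something is new, unique, unknown or untested is made for them only; others in the source may bear on it.

In an ADME assay on BaF3 cells (Mus musculus) for antiproliferative activity, read by CCK-8 assay, with a stated time of 72 h (a higher number here means a weaker inhibitor of growth, a lower number a stronger inhibitor of growth), compound 1 (`O=C(CCSc1ccc2c(/C=C/c3ccccn3)n[nH]c2c1)Nc1ccc(F)c(C(F)(F)F)c1`) gives 610 nM and compound 2 (`Cc1ccc(NC(=O)CCSc2ccc3c(/C=C/c4ccccn4)n[nH]c3c2)cc1C(F)(F)F`) gives 530 nM, two values within the scatter of each other. Compound 3 (`CN1CCN(Cc2ccc(NC(=O)CCSc3ccc4c(/C=C/c5ccccn5)n[nH]c4c3)cc2C(F)(F)F)CC1`) gives 2480 nM, the highest of the three numbers and so the weakest inhibitor of growth in this small set.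

Compound 4 (`CCN1CCN(Cc2ccc(NC(=O)CCSc3ccc4c(/C=C/c5ccccn5)n[nH]c4c3)cc2C(F)(F)F)CC1`) differs from compound 3 in one place: methyl in place of hydrogen on a saturated chain carbon bound to an amine nitrogen in a ring. The 4-methylpiperazin-1-yl group thus becomes 4-ethylpiperazin-1-yl. Among the measured compounds shown here, no measured step makes this exact change, so the guidance is indirect. Placing methyl in place of fluoro on an aromatic carbon gave a 1.2-fold lower number from compound 1 to compound 2 (0.06 log units; within the scatter), a small swap with no clear effect. Installing the whole (4-methylpiperazin-1-yl)methyl group gave larger, modest steps: a 4.1-fold higher number from compound 1 to compound 3 (0.61 log units; beyond the scatter) and a 4.7-fold higher number from compound 2 to compound 3 (0.67 log units; beyond the scatter). Those steps brought in an entire substituent, whereas here the group stays in place and only its end is extended. The change therefore resembles the small swap more closely, and no step beyond the scatter is expected in this assay. The data cannot exclude a modest move in either direction.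

The expected step is a 1.1-fold lower number from compound 3 to compound 4 (0.05 log units; within the scatter). For compound 4 the estimated value is 2200 nM, with an expected range from 1000 nM to 4500 nM.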

Compound 4, concentration for 50% growth inhibition: 840 nM
Compound 4: the middle estimate sits 2.6-fold (0.42 log units) above what was measured, and the stated range ends above it.
By their numbers in this assay, from the lowest: compounds 2, 1 and 4 (each within the scatter of the next); then compound 3.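

In this assay the place on a saturated chain carbon bound to an amine nitrogen in a ring proves sensitive: the single added carbon that turns 4-methylpiperazin-1-yl into 4-ethylpiperazin-1-yl gives a 3.0-fold lower number from compound 3 to compound 4 (0.47 log units; beyond the scatter) in this small set. The higher number seen with (4-methylpiperazin-1-yl)methyl therefore does not carry over to its ethyl counterpart, since (4-ethylpiperazin-1-yl)methyl in place of fluoro gives a 1.4-fold higher number from compound 1 to compound 4 (0.14 log units; within the scatter) and the matching change from the methyl-bearing compound gives a 1.6-fold higher number from compound 2 to compound 4 (0.20 log units; within the scatter) as well. Nothing available explains why one methyl group has this effect on growth inhibition.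

The compounds shown leave open whether the trend continues or reverses with other groups at this place, such as a longer propyl chain, a branched isopropyl group or a 2-hydroxyethyl chain. They also leave open what plain piperazin-1-yl, with only hydrogen at this place, would give in this assay and so whether methyl or ethyl is the real departure from it.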